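This account rests on a few compounds, and the source may have more. Where it says the series, first, only, none or still open, it means among the compounds named here.

Measured so far:
Compound 1 `CCn1c(C(=O)NCCCN(C)C)ccc1C(CC)(CC)c1ccc(OCCC(O)(CC)CC)c(C)c1`: 110 nM
Compound 2 `CCN(CC)CCNC(=O)c1ccc(C(CC)(CC)c2ccc(OCCC(O)(CC)CC)c(C)c2)n1CC`: 230 nM
Compound 3 `CCn1c(C(=O)NCCN)ccc1C(CC)(CC)c1ccc(OCCC(O)(CC)CC)c(C)c1`: 1590 nM

These three share one core and differ only at the amide end. In a functional assay on HepG2 cells (Homo sapiens) for antiproliferative activity, read by MTT assay, with a stated time of 48 h (a higher number here means a weaker inhibitor, a lower number a stronger inhibitor), compound 3 gives the highest number of the three, the weakest inhibitor here. Compound 4 `CCn1c(C(=O)Nc2ccc(OC(F)(F)F)cc2)ccc1C(CC)(CC)c1ccc(OCCC(O)(CC)CC)c(C)c1` carries 4-(trifluoromethoxy)phenyl in place of 2-aminoethyl on an amide-type nitrogen. The steps measured so far all swap one amine for another on the chain: a 14-fold higher number from compound 1 to compound 3 (1.16 log units; beyond the scatter) and a 6.9-fold higher number from compound 2 to compound 3 (0.84 log units; beyond the scatter), both beyond the scatter. Among the measured compounds shown here, none of them replaces the chain with an aromatic ring, so no measured step bears directly on this change. The expectation is therefore uncertain and wide: compound 4 is estimated at 1000 nM (range 200 nM to 5000 nM), an expected step of a 1.6-fold lower number from compound 3 to compound 4 (0.20 log units; within the scatter).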

Compound 4, half-maximal inhibitory concentration: > 50000 nM
Compound 4 gave a limit, no number; the forecaster's own chance of this, stated with the estimate: 10%; middle value at least 50-fold (1.69 log units) away from the limit.
By their numbers in this assay, from the lowest: compound 1; then compound 2; then compound 3. At a limit, above all of these: compound 4.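

In this assay compound 4 gives a limit and not a number: the limit of > 50000 nM in this assay, at which 1 of the 4 values shown sits.

On the amide-type nitrogen, 4-(trifluoromethoxy)phenyl costs far more than any swap of one amine for another on the chain did, with an at least 31-fold higher number from compound 3 to compound 4 (1.49 log units; beyond the scatter), an at least 210-fold higher number from compound 2 to compound 4 (2.33 log units; beyond the scatter) and an at least 450-fold higher number from compound 1 to compound 4 (2.65 log units; beyond the scatter). At this position, the three chains that end in an amine all give measurable numbers, while this aromatic ring does not.

The compounds shown cannot separate the presence of the ring from the absence of an amine. A plain phenyl or a 4-(dimethylamino)phenyl on the same nitrogen would bear on that question.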